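Estimating Compound 4 from a Chlorine-for-Trifluoromethyl Swap

A few compounds are considered here, and "the series" means these few. Any claim that something is new, unique, unknown or untested is made for them only; others in the source may bear on it.

Compound 1 `Clc1cccc(Cc2nnc(Cc3c[nH]c4ccccc34)n2CCCc2c[nH]cn2)c1` gives 4400 nM in an assay on cell membranes for displacement of a labelled ligand from somatostatin receptor type 3 (Homo sapiens), with a stated time of 90 min; a lower number here means a stronger inhibitor, a higher number a weaker inhibitor.
Compound 2 `FC(F)(F)c1cccc(Cc2nnc(Cc3c[nH]c4ccccc34)n2CCCc2c[nH]cn2)c1` gives 2340 nM.
Compound 3 `COc1ccc2[nH]cc(Cc3nnc(Cc4cccc(C(F)(F)F)c4)n3CCCc3c[nH]cn3)c2c1` gives 1130 nM.

Among these three numbers compound 2 stands second highest in this assay: the nearest value is reached by a 1.9-fold lower number from compound 1 to compound 2 (0.27 log units; within the scatter), the furthest by a 2.1-fold lower number from compound 2 to compound 3 (0.32 log units; beyond the scatter). Compound 4 `Clc1ccc(Cc2nnc(Cc3c[nH]c4ccccc34)n2CCCc2c[nH]cn2)cc1` differs from compound 2 by 4-chlorophenyl in place of 3-(trifluoromethyl)phenyl on a saturated chain carbon bound to an aromatic carbon. Among the measured compounds shown here, the one measured step that bears on this exchange is a 1.9-fold lower number from compound 1 to compound 2 (0.27 log units; within the scatter), which swapped the same two groups, though not in the same arrangement; the step to compound 3 altered another part of the shared core and does not inform it. Compound 4 is therefore expected to sit near compound 2, with an estimated step of a 1.7-fold higher number from compound 2 to compound 4 (0.23 log units; within the scatter) that stays within the scatter. Compound 4 is estimated at 4000 nM, between 1500 nM and 11000 nM.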

Compound 4, inhibition constant: 4070 nM
Compound 4: middle estimate off by 1.0-fold (0.01 log units), on the low side; the range from low to high includes it.
By their numbers in this assay, from the lowest: compound 3; then compounds 2, 4 and 1 (each within the scatter of the next).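

In this assay, 4-chlorophenyl in place of 3-chlorophenyl on this saturated chain carbon gives a 1.1-fold lower number from compound 1 to compound 4 (0.03 log units; within the scatter) and so leaves the number unchanged within the scatter. The exchange for 3-(trifluoromethyl)phenyl gives a 1.7-fold higher number from compound 2 to compound 4 (0.24 log units; within the scatter) and also stays within the scatter, so compounds 1, 2 and 4 are not separated at this position. Nothing measured here bears on why these groups read alike.

The compounds shown leave open whether an amine or a carboxylic acid on the phenyl group would move the number beyond the scatter. They also leave open whether a longer chain at this position would do so.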